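This account rests on a few compounds, and the source may have more. Where it says the series, first, only, none or still open, it means among the compounds named here.

Series values in a functional assay (aorta) for inhibition, with Rattus norvegicus as the target, with a stated time of 8 days; on this read-out lower numbers stand for stronger inhibition and higher numbers for weaker inhibition:
- compound 1 `Cc1nsc(-c2ccc(N3CCN(c4cccc(Cl)c4)CC3)nn2)n1`: 0.6 nM
- compound 2 `Cc1nsc(-c2ccc(N3CCN(c4cccc(F)c4)CC3)nn2)n1`: 6 nM
- compound 3 `Cc1nsc(-c2ccc(N3CCN(c4cccc(C#N)c4)CC3)nn2)n1`: 3 nM

Compound 3, at 3 nM, does not separate from the fluoro analogue, with a 2.0-fold lower number from compound 2 to compound 3 (0.30 log units; within the scatter). The chloro analogue holds the lowest number of the set, with a 5.0-fold higher number from compound 1 to compound 3 (0.70 log units; beyond the scatter).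

The next analogue is compound 4 `Cc1nsc(-c2ccc(N3CCN(c4cccc(N)c4)CC3)nn2)n1`, which takes 3-cyanophenyl to 3-aminophenyl, amino in place of cyano on an aromatic carbon, meta to a large group: amino in place of cyano on an aromatic carbon.

Among the measured compounds shown here, no measured step involves amino, so the evidence is indirect. All three measured steps are changes at this same place on the same core. Moving away from chloro gave a 10-fold higher number from compound 1 to compound 2 (1.00 log units; beyond the scatter), a modest step, and the cyano change from chloro was also modest. Fluoro and cyano could not be told apart in this assay. For the measured compounds named here, on three compounds, this shows only that swaps at this place can shift the number by a modest amount. A step of similar size is therefore expected, more likely upward than downward, though the direction is weakly supported.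

The expected change is a 4.0-fold higher number from compound 3 to compound 4 (0.60 log units; beyond the scatter). Compound 4 is estimated at 12 nM, with an expected range of 2 nM to 70 nM.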

Compound 4, half-maximal inhibitory concentration: > 100 nM
Compound 4: no number, only a limit; the forecaster's own chance of this, stated with the estimate: 5%; middle value at least 8.3-fold (0.92 log units) from the limit.
By their numbers in this assay, from the lowest: compound 1; then compounds 3 and 2 (each within the scatter of the next). At a limit, above all of these: compound 4.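

In this assay compound 4 carries no number, only a limit: the limit of > 100 nM in this assay, at which 1 of the 4 values shown sits.

The numbers at this place are therefore not confined to the modest shifts seen among chloro, fluoro and cyano. Amino gives a large step against each of the three earlier groups (an at least 33-fold higher number from compound 3 to compound 4 (1.52 log units; beyond the scatter)) (an at least 16-fold higher number from compound 2 to compound 4 (1.22 log units; beyond the scatter)) (an at least 160-fold higher number from compound 1 to compound 4 (2.22 log units; beyond the scatter)). It is also the one change shown that puts a hydrogen-bond donor at this place where cyano has none, although a single compound cannot tie the large steps to that donor rather than to anything else about the amino group.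

On these data alone, the full size of these steps stays open, and so does whether any group carrying a hydrogen-bond donor would behave like amino here. A hydroxyl group, a methoxy group and a dimethylamino group at the same place on the shared core are the comparisons that would separate these readings.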